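Fluoro added to compound 1: expected cytotoxicity

This account rests on a few compounds, and the source may have more. Where it says the series, first, only, none or still open, it means among the compounds named here.

Compound 1 `COc1ccc(-n2ccc(=O)c(C(=O)Nc3ccc(Oc4ccnc5c4ccn5C)cc3)n2)cc1` has been run in a functional assay on PC-3 cells (Homo sapiens) for cytotoxicity, read by MTT assay, with a stated time of 72 h; on this read-out lower numbers stand for stronger inhibition and higher numbers for weaker inhibition. In this assay compound 1 gives > 60000 nM, which is a limit of the assay and not a number. One of the two recorded values sits at that limit, (the limit of > 60000 nM in this assay, at which 1 of the 2 values shown sits). Compound 2 `Cn1ccc2c(Oc3ccc(NC(=O)c4nn(-c5ccc(Cl)c(F)c5)ccc4=O)cc3)ccnc21` gives 32700 nM in this assay. Among the compounds with values here, the single measured step, an at least 1.8-fold lower number from compound 1 to compound 2 (0.26 log units; that floor lies within the scatter), replaces the group on the aromatic nitrogen and is the only comparison available in the set.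

Compound 3 `COc1ccc(-n2ccc(=O)c(C(=O)Nc3ccc(Oc4ccnc5c4ccn5C)c(F)c3)n2)cc1` differs from compound 1 by fluoro in place of hydrogen on an aromatic carbon. Within the data shown here, no measured step touches that place; the step from compound 1 to compound 2 alters a different part of the molecule and does not bear on a change at the anilide ring. With compound 1 known only as a limit, no direction can be read for this change, and no step beyond the scatter is expected in this assay. The expected step is a number no higher from compound 1 to compound 3 (the limit leaves the size open). The estimate for compound 3 in this assay is 60000 nM, with a range from 25000 nM to 150000 nM, and a real chance that only a limit is reported again.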

Compound 3, half-maximal inhibitory concentration: > 60000 nM
Compound 3: a limit, no number; the forecaster's own chance of this, stated with the estimate: 65%; the middle value lies on the limit itself.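

Compound 3, like compound 1, reads only as a limit in this assay, so no step between the two compounds can be read: the limit of > 60000 nM in this assay, at which 2 of the 3 values shown sit.

From the compounds shown here alone, what fluoro in place of hydrogen on an aromatic carbon does to cytotoxicity stays open, including whether the change would register on a compound with a measurable value, such as compound 2.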